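Swapping 1-methylhexyl for (oxolan-2-yl)methyl on the nitrogen

A few compounds are considered here, and "the series" means these few. Any claim that something is new, unique, unknown or untested is made for them only; others in the source may bear on it.

Measured so far in a functional assay on K562 cells (Homo sapiens) for antiproliferative activity, read by CellTiter-Glo, with a stated time of 72 h; a higher number here means that more compound is needed for the effect, a lower number that less compound is needed:
Compound 1 `CC(C)(C)CCNc1ncnc2c1ncn2[C@@H]1O[C@H](COS(N)(=O)=O)[C@@H](O)[C@H]1O` gives 929 nM
Compound 2 `CCCCCC(C)Nc1ncnc2c1ncn2[C@@H]1O[C@H](COS(N)(=O)=O)[C@@H](O)[C@H]1O` gives 203 nM

Compound 2 stands lowest of the two measured numbers. Compound 3 `NS(=O)(=O)OC[C@H]1O[C@@H](n2cnc3c(NCC4CCCO4)ncnc32)[C@H](O)[C@@H]1O` differs from it by (oxolan-2-yl)methyl in place of 1-methylhexyl on a nitrogen on an aromatic ring and carries (oxolan-2-yl)methyl in place of 1-methylhexyl on a nitrogen on an aromatic ring. Among the measured compounds shown here, the only measured step bearing on this changed the group on that same nitrogen (a 4.6-fold lower number from compound 1 to compound 2 (0.66 log units; beyond the scatter)) and is modest. For the measured compounds named here, no measured compound carries (oxolan-2-yl)methyl, so that step is only a rough guide. Going by the values given here, compound 1, the sole comparison, sits higher at 929 nM, so a step of similar size toward a higher number is expected in this assay here. For compound 3 the estimated value is 600 nM (expected range 150 nM to 2500 nM). That estimate means a 3.0-fold higher number from compound 2 to compound 3 (0.47 log units; beyond the scatter) as the expected change.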

Compound 3, half-maximal effective concentration: > 1000 nM
Compound 3: only a limit was reported; the forecaster's own chance of this, stated with the estimate: 2%; at least 1.6-fold (0.22 log units) between middle value and limit.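

In this assay compound 3 gives only a limit, not a number: the limit of > 1000 nM in this assay, at which 1 of the 3 values shown sits.

Putting (oxolan-2-yl)methyl in place of 1-methylhexyl on this nitrogen, which brings in a ring and a hydrogen-bond acceptor, gives an at least 4.9-fold higher number from compound 2 to compound 3 (0.69 log units; beyond the scatter), so the gain seen with 1-methylhexyl does not carry over to this group. Against the 3,3-dimethylbutyl compound the change gives an at least 1.0-fold higher number from compound 1 to compound 3 (0.03 log units; that floor lies within the scatter), and with that floor the order of those two stays unsettled.

Going by these compounds, it remains open how far compound 3 lies past its limit. On these data alone, it also remains open whether the ring or its oxygen goes with the rise, which a cyclopentylmethyl group on the same nitrogen would separate.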